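Pyrazolone amides on a thienopyrimidine ether: fluorophenyl swap

A few compounds are considered here, and "the series" means these few. Any claim that something is new, unique, unknown or untested is made for them only; others in the source may bear on it.

Measured so far:
compound 1 `Cc1cc(=O)n(-c2cccc(F)c2)nc1C(=O)Nc1ccc(Oc2ncnc3sccc23)cc1`, 27200 nM
compound 2 `Cc1cc(=O)n(-c2ccccc2C(F)(F)F)nc1C(=O)Nc1ccc(Oc2ncnc3sccc23)c(F)c1`, 13800 nM

In a functional assay on MCF7 cells (Homo sapiens) for cytotoxicity, read by MTT assay, with a stated time of 72 h (a higher number here means a weaker inhibitor, a lower number a stronger inhibitor), compound 1 gives 27200 nM and compound 2 gives 13800 nM. Compound 2 has the lower of the two numbers, but its gap to compound 1 is within the scatter, so no order between them can be claimed. Within the data shown here, the two compounds differ in two places at once, so no single step between them is known.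

Compound 3 `Cc1cc(=O)n(-c2cccc(F)c2)nc1C(=O)Nc1ccc(Oc2ncnc3sccc23)c(F)c1` differs from compound 2 in one place: 3-fluorophenyl in place of 2-(trifluoromethyl)phenyl on an aromatic nitrogen. Compound 1 carries the same 3-fluorophenyl group, and its value in this assay sits within the scatter of compound 2, so no step beyond the scatter is expected from compound 2 to compound 3, in either direction.

Compound 3 is therefore expected to give 20000 nM in this assay, in a range from 8000 nM to 50000 nM, which means an estimated step of a 1.4-fold higher number from compound 2 to compound 3 (0.16 log units; within the scatter).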

Compound 3, half-maximal inhibitory concentration: 17300 nM
For compound 3 the middle estimate is 1.2-fold (0.06 log units) above the measured one; low and high end bracket the measured number.
By their numbers in this assay, from the lowest: compounds 2, 3 and 1 (each within the scatter of the next).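

In this assay, among these compounds, compound 3 supplies the first single-place comparisons. Putting 3-fluorophenyl in place of 2-(trifluoromethyl)phenyl on the aromatic nitrogen gives a 1.3-fold higher number from compound 2 to compound 3 (0.10 log units; within the scatter), and putting fluoro in place of hydrogen on an aromatic carbon gives a 1.6-fold lower number from compound 1 to compound 3 (0.20 log units; within the scatter), so neither change separates its pair of compounds. No measurement is at hand that bears on a cause for these results.

From the compounds shown here alone, the aromatic nitrogen carries only fluorinated phenyl groups here, so it remains open whether a methoxyphenyl or aminophenyl group, or a simple alkyl chain in place of the ring, would give a step beyond the scatter. Also open, going by these compounds, is whether a chloro or methoxy group in place of the fluoro on the aromatic carbon would do so.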